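Replacing a propargyl group with a 4-cyanobenzyl group

The source may report more compounds than this note shows. Statements on the series, on what has been measured and on what is new or still open speak of the compounds shown alone.

Compound 1, `CCN(CC)c1ccc2cc(C(=O)c3ccc(N4CCN(C(=O)CN5CCN(C(=O)CCl)CC5)CC4)cc3)oc2c1`, gives in a functional assay on HCT-116 cells (Homo sapiens) for cytotoxicity, read by MTT assay, with a stated time of 48 h (on this read-out lower numbers stand for stronger inhibition and higher numbers for weaker inhibition), a value of > 40000 nM, which is a limit of the assay and not a number.
Compound 2, `CCN(CC)c1ccc2cc(C(=O)c3ccc(N4CCN(C(=O)CN5CCN(C(=O)/C=C/c6ccccc6)CC5)CC4)cc3)oc2c1`, gives 6810 nM.
Compound 3, `C#CCN1CCN(CC(=O)N2CCN(c3ccc(C(=O)c4cc5ccc(N(CC)CC)cc5o4)cc3)CC2)CC1`, gives 17700 nM.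

Of the two numbers in hand, compound 3 stands highest; its nearest neighbour is compound 2, and the step of a 2.6-fold higher number from compound 2 to compound 3 (0.41 log units; beyond the scatter). Compound 1 sits at the limit of > 40000 nM in this assay, at which 1 of the 3 values shown sits, so the step of an at least 2.2-fold lower number from compound 1 to compound 3 (0.35 log units; beyond the scatter) and the step of an at least 5.8-fold lower number from compound 1 to compound 2 (0.76 log units; beyond the scatter) are bounds rather than exact sizes.

Compound 4, `CCN(CC)c1ccc2cc(C(=O)c3ccc(N4CCN(C(=O)CN5CCN(Cc6ccc(C#N)cc6)CC5)CC4)cc3)oc2c1`, differs from compound 3 in one place: 4-cyanophenyl in place of ethynyl on a saturated chain carbon bound to an amine nitrogen in a ring. Going by the values given here, the steps that bear on this change are those that altered the group on the same ring nitrogen, namely the step from compound 1 to compound 3 and the step from compound 2 to compound 3, both of modest size. A larger aromatic group on this position, as in compound 2, went with a lower number than the propargyl group of compound 3. The step to compound 4 is therefore expected to lower the number modestly, a 2.2-fold lower number from compound 3 to compound 4 (0.34 log units; beyond the scatter). The estimated value for compound 4 is 8000 nM, with a range from 3000 nM to 25000 nM.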

Compound 4, half-maximal inhibitory concentration: > 40000 nM
Compound 4 was reported as a limit; the forecaster's own chance of this, stated with the estimate: 10%; at least 5.0-fold (0.69 log units) between middle value and limit.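

On the amine nitrogen in a ring, the change from propargyl to 4-cyanobenzyl gives an at least 2.2-fold higher number from compound 3 to compound 4 (0.35 log units; beyond the scatter), so in this assay an added aromatic ring does not by itself go with a lower number. Compound 2 stands against any simple link between an aromatic ring and a lower number: the change to 4-cyanobenzyl on the same nitrogen gives an at least 5.8-fold higher number from compound 2 to compound 4 (0.76 log units; beyond the scatter), so the lower number of compound 2 goes with its whole (2-phenylethenyl)carbonyl group and not with the presence of a phenyl ring alone. Both steps are bounds, and the step from compound 1 to compound 4 cannot be read, because each of these two compounds rests at a limit and not at a number: the limit of > 40000 nM in this assay, at which 2 of the 4 values shown sit.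

From the compounds shown here alone, it remains open whether the nitrile or the benzyl part of 4-cyanobenzyl goes with the higher number, which an unsubstituted benzyl group or a 4-methoxybenzyl group on this nitrogen would address. Going by these compounds, it is also open whether the carbonyl or the double bond of compound 2 matters more, a question that a benzoyl group or a 3-phenylpropanoyl group would bear on.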